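From tert-Butoxy to Isopropoxy: A Small Trim

The source may hold more compounds than are shown below. What is called first, only, known or untested is meant among the compounds shown, and "the series" means these compounds.

Measured so far:
Compound 1 `C=Cc1cn2ncc(-c3ccnc(OC)c3)c2nc1NC`: 190 nM
Compound 2 `COc1cn2ncc(-c3ccnc(OC(C)(C)C)c3)c2nc1-c1cnn(C)c1`: 800 nM

Both compounds were tested in an assay on isolated protein for inhibition of activin receptor type-2A (Homo sapiens), read by 33P incorporation, with a stated time of 20 min, in the presence of a further agent that is not named here; on this read-out higher numbers stand for weaker inhibition and lower numbers for stronger inhibition. Compound 2 stands at the higher of the two numbers, so it is the weaker inhibitor of the pair, and the gap to compound 1 lies beyond the usual scatter. The two compounds differ in several places at once, so the values alone say nothing about which of those changes matters.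

Compound 3 `COc1cn2ncc(-c3ccnc(OC(C)C)c3)c2nc1-c1cnn(C)c1` has not yet been measured in this assay. It differs from compound 2 in one place only: hydrogen in place of methyl on a saturated chain carbon bound to an oxygen on an aromatic ring and two saturated chain carbons. Within the data shown here, with no single-point step between measured compounds to lean on, the size and direction of this change cannot be read from the data; a step of modest size is expected, most likely within the scatter, in either direction. Compound 3 is therefore estimated at about 650 nM, with a plausible range from 220 nM to 2000 nM, which means an expected step of a 1.2-fold lower number from compound 2 to compound 3 (0.09 log units; within the scatter).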

Compound 3, half-maximal inhibitory concentration: 2300 nM
Beside the measured number, compound 3's estimate is 3.5-fold (0.55 log units) below it, and the stated range ends below it.
By their numbers in this assay, from the lowest: compound 1; then compound 2; then compound 3.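

In this assay, trimming tert-butoxy to isopropoxy gives a 2.9-fold higher number from compound 2 to compound 3 (0.46 log units; beyond the scatter), so the loss of this one methyl goes with weaker inhibition. Among these compounds, this is the first comparison here in which only one place changes, and it shows that this position responds to a difference of a single carbon, with the larger tert-butyl group giving the stronger inhibition of the pair. No accompanying measurement in this set bears on why the loss of the methyl has this effect.

One step between two compounds gives a direction for this single change, but it does not establish a trend across the position, and it says nothing about how the same trim would behave if other parts of the molecule were different. It also leaves open how inhibition would respond to other groups on this oxygen, such as an ethyl group, a cyclobutyl ring or a longer chain, and whether any of them would match or improve on tert-butyl.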